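The source may hold more compounds than are shown below. What is called first, only, known or untested is meant among the compounds shown, and "the series" means these compounds.

Working notes on a series of three measured analogues sharing one core. In an assay on microsomes from liver for inhibition of sterol O-acyltransferase 1 (Rattus norvegicus) (a lower number here means a stronger inhibitor, a higher number a weaker inhibitor), compound 1 `CCCCCCCOc1cc(-c2ccccc2)c(-c2ccccc2)nn1` gives 58000 nM, compound 2 `CCCCCCCSc1cc(-c2ccccc2)c(-c2ccccc2)nn1` gives 76000 nM, and compound 3 `CCCCCC[S+]([O-])c1cc(-c2ccccc2)c(-c2ccccc2)nn1` gives 75000 nM. Compound 3 stands second highest of the three numbers, with a 1.0-fold lower number from compound 2 to compound 3 (0.01 log units; within the scatter) and a 1.3-fold higher number from compound 1 to compound 3 (0.11 log units; within the scatter) both within the scatter. Compound 4 `O=C(O)CCCCCSc1cc(-c2ccccc2)c(-c2ccccc2)nn1` carries a group of 9 heavy atoms (6 carbon, 2 oxygen, 1 sulfur; no ring) in place of a group of 8 heavy atoms (6 carbon, 1 oxygen, 1 sulfur; no ring), on an aromatic carbon. The measured steps that bear on this exchange of the chain are a 1.3-fold higher number from compound 1 to compound 2 (0.12 log units; within the scatter), a 1.3-fold higher number from compound 1 to compound 3 (0.11 log units; within the scatter) and a 1.0-fold lower number from compound 2 to compound 3 (0.01 log units; within the scatter), none of them beyond the scatter. In this assay no step beyond the scatter is therefore expected, in either direction. The expected step is no change at the digits printed from compound 3 to compound 4 (within the scatter). Compound 4 is estimated at 75000 nM in this assay, with a range from 35000 nM to 160000 nM.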

Compound 4, half-maximal inhibitory concentration: > 300000 nM
Compound 4: only a limit was reported; the forecaster's own chance of this, stated with the estimate: 20%; middle value at least 4.0-fold (0.60 log units) from the limit.
By their numbers in this assay, from the lowest: compounds 1, 3 and 2 (each within the scatter of the next). At a limit, above all of these: compound 4.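

In this assay, going by these compounds alone, the (5-carboxypentyl)sulfanyl chain is the first at this aromatic carbon to give a step beyond the scatter, with an at least 4.0-fold higher number from compound 3 to compound 4 (0.60 log units; beyond the scatter), an at least 3.9-fold higher number from compound 2 to compound 4 (0.59 log units; beyond the scatter) and an at least 5.1-fold higher number from compound 1 to compound 4 (0.71 log units; beyond the scatter). The changes among compounds 1, 2 and 3 all stayed within the scatter, so this position is not indifferent to every exchange of the chain, and carboxy in place of ethyl on the saturated chain weakens inhibition. The value for compound 4 is only a limit: the limit of > 300000 nM in this assay, at which 1 of the 4 values shown sits.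

Still open, on these data alone, is whether an amine or a methyl ester on the same chain would behave like compound 4 or like compounds 1, 2 and 3. Also open, as far as these compounds go, is whether a longer chain carrying the carboxylic acid would recover inhibition.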